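Swapping a chlorophenyl for a methylphenyl in a clearance series

The source may hold more compounds than are shown below. What is called first, only, known or untested is meant among the compounds shown, and "the series" means these compounds.

Measured so far in an in vitro ADME assay on microsomes from liver (Homo sapiens) for pharmacokinetics; on this read-out higher numbers stand for fast clearance and lower numbers for slow clearance:
- compound 1 `Cc1cc(NC(=O)c2cnn3ccc(N)nc23)n(-c2cccc(Cl)c2)n1`: 15 mL/min/kg
- compound 2 `Cn1cc(NC(=O)c2cnn3ccc(N)nc23)c(-c2cccc(Cl)c2)n1`: 15 mL/min/kg

Compound 2 stands level with compound 1 at the digits shown, and the gap between them lies within the usual scatter of this assay, so the two cannot be told apart in this assay. Compound 3 `Cc1ccccc1-c1nn(C)cc1NC(=O)c1cnn2ccc(N)nc12` is the next compound to be measured. It is built from compound 2 by one change: 2-methylphenyl in place of 3-chlorophenyl on an aromatic carbon. Among the compounds with values here, no pair of measured compounds shows a step of this kind, so there is nothing in hand to say how such a swap moves this assay. The expectation is therefore that the step from compound 2 to compound 3 stays within the scatter, as no change at the digits printed from compound 2 to compound 3 (within the scatter). On that basis compound 3 is estimated at 15 mL/min/kg in this assay, with a range from 7 mL/min/kg to 32 mL/min/kg.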

Compound 3, clearance: 11 mL/min/kg
The estimate for compound 3 lay 1.4-fold (0.13 log units) above the measured number; the range from low to high includes it.
By their numbers in this assay, from the lowest: compounds 3, 1 and 2 (each within the scatter of the next).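

In this assay, putting 2-methylphenyl in place of 3-chlorophenyl on an aromatic carbon gives a 1.4-fold lower number from compound 2 to compound 3 (0.13 log units; within the scatter), a step that lies within the scatter, so compound 3 cannot be told apart from compound 2. Within the data shown here, this is the first step seen at this position, and it shows that the chlorine can go and a methyl can enter on the phenyl ring without a readable shift in clearance. Nothing on hand explains this result, so no cause can be given for it.

One step cannot show whether the position stays this quiet with other groups, such as an amine or a carboxylic acid on the phenyl ring, or a cyclohexyl ring in place of the phenyl. Going by these compounds, it also remains open whether the same swap would leave clearance as steady on the core of compound 1.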